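Notes on the amine-substituted core series, whole-organism inhibition

A few compounds are considered here, and "the series" means these few. Any claim that something is new, unique, unknown or untested is made for them only; others in the source may bear on it.

Measured compounds:
compound 1, `COc1ccc(Nc2[nH]c(C)nc3nccc2-3)cc1` — 661000000 nM
compound 2, `Cc1nc2nccc-2c(NC(C)C)[nH]1` — 550000000 nM

Both compounds were tested in a functional assay on the whole organism for inhibition, with Nicotiana tabacum as the target; a higher number here means a weaker inhibitor, a lower number a stronger inhibitor. Compound 2 gives 550000000 nM, the lower of the two numbers recorded in this assay; compound 1 gives 661000000 nM, and the gap between the two lies within the scatter, so no order between them can be claimed. Both numbers sit at the very weak end of the scale.

Compound 3, `COCCNc1[nH]c(C)nc2nccc1-2`, has not yet been measured. Relative to compound 2 the change is 2-methoxyethyl in place of isopropyl on a nitrogen on an aromatic ring. For the measured compounds named here, no step between measured compounds is available to calibrate a change of this kind, and the two measured values together give no sign that variation at this nitrogen moves the number by much.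

The expectation is therefore a step of no more than the scatter, with the estimated step being no change at the digits printed from compound 2 to compound 3 (within the scatter). For compound 3 the estimated value in this assay is 550000000 nM, with an expected range from 250000000 nM to 1200000000 nM.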

Compound 3, half-maximal inhibitory concentration: 166000000 nM
For compound 3 the middle estimate is 3.3-fold (0.52 log units) above the measured one, and the stated range ends above it.
By their numbers in this assay, from the lowest: compound 3; then compounds 2 and 1 (each within the scatter of the next).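

In this assay the 2-methoxyethyl in place of isopropyl on a nitrogen on an aromatic ring gives a 3.3-fold lower number from compound 2 to compound 3 (0.52 log units; beyond the scatter) and so moves the number beyond the scatter, a step in the direction of stronger inhibition. Compound 1 and compound 2 lie within the scatter of each other and gave no sign of this, so the nitrogen substituent is now seen to matter in this series, though only modestly, and compound 3 at 166000000 nM remains at the very weak end of the scale. The compounds shown offer nothing that explains this step, and no supporting measurement bears on it.

The change brings in one oxygen and one hydrogen-bond acceptor along with one more heavy atom, and the compounds shown do not separate the contribution of the oxygen from that of the added chain length. A plain butyl chain would address that question, while a 2-hydroxyethyl group, a 3-methoxypropyl chain or a chain ending in an amine would show how far the step extends at this nitrogen.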